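Five-ring heteroaryl swaps on the benzyl urea series

The source may report more compounds than this note shows. Statements on the series, on what has been measured and on what is new or still open speak of the compounds shown alone.

Measured compounds:
compound 1 `Cc1cc(C)c(NC(=O)N(Cc2ccc(-c3n[nH]c(C)n3)cc2)C2CCCCCC2)c(C)c1`, 120 nM in an assay on microsomes from intestine for inhibition of acyl-CoA:cholesterol acyltransferase (Oryctolagus cuniculus); a higher number here means a weaker inhibitor, a lower number a stronger inhibitor
compound 2 `Cc1cc(C)c(NC(=O)N(Cc2ccc(-c3cccnc3)cc2)C2CCCCCC2)c(C)c1`, 130 nM in this assay
compound 3 `Cc1cc(C)c(NC(=O)N(Cc2cccc(-c3cn[nH]c3)c2)C2CCCCCC2)c(C)c1`, 38 nM in this assay

Compound 2 gives the highest of the three numbers in this assay. Compound 1 lies nearest to it; the step of a 1.1-fold higher number from compound 1 to compound 2 (0.03 log units; within the scatter) is within the scatter, so the two are not distinguished. For the measured compounds named here, compound 3 is furthest from compound 2, with a lower number beyond the scatter, but it differs from compound 2 in more than one place and no single step is drawn from that pair.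

Compound 4 `Cc1cc(C)c(NC(=O)N(Cc2ccc(-c3ccnn3C)cc2)C2CCCCCC2)c(C)c1` is not yet measured. It differs from compound 2 by 1-methyl-1H-pyrazol-5-yl in place of pyridin-3-yl on an aromatic carbon. Going by the values given here, the only measured step that bears on this change is a 1.1-fold higher number from compound 1 to compound 2 (0.03 log units; within the scatter), in which one small heteroaromatic ring replaced another at the same place without a change beyond the scatter. On that basis the change to compound 4 is expected to leave the number where it is, with no step beyond the scatter in either direction. This corresponds to an expected step of a 1.2-fold lower number from compound 2 to compound 4 (0.07 log units; within the scatter). For compound 4 the estimate in this assay is 110 nM, with a range from 45 nM to 270 nM.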

Compound 4, half-maximal inhibitory concentration: 24 nM
The estimate for compound 4 lay 4.6-fold (0.66 log units) above the measured number; the whole stated range lies above it.
By their numbers in this assay, from the lowest: compounds 4 and 3 (each within the scatter of the next); then compounds 1 and 2 (each within the scatter of the next).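

In this assay this aromatic carbon, para to a large group, is not indifferent to which ring it carries: the swap of pyridin-3-yl for 1-methyl-1H-pyrazol-5-yl gives a 5.4-fold lower number from compound 2 to compound 4 (0.73 log units; beyond the scatter) and the swap of 5-methyl-1H-1,2,4-triazol-3-yl for the same pyrazole gives a 5.0-fold lower number from compound 1 to compound 4 (0.70 log units; beyond the scatter) on the same core. The earlier pair of heteroaromatic rings had shown no separation, so that result did not hold for heteroaromatic rings in general. The heavy-atom count is unchanged between pyridin-3-yl and 1-methyl-1H-pyrazol-5-yl, so ring identity matters here without any change in that count.

As far as these compounds go, whether the gain depends on the ring itself or on its methyl remains open, and an ethyl on the pyrazole nitrogen or a 1-methyl-1H-imidazol-5-yl ring would test this. No measurement here accounts for the difference.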